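Shortening the alkyl chain on a shared nucleoside core

A few compounds are considered here, and "the series" means these few. Any claim that something is new, unique, unknown or untested is made for them only; others in the source may bear on it.

This account follows a single change in a functional assay on L1210 cells (Mus musculus); on this read-out higher numbers stand for weaker inhibition and lower numbers for stronger inhibition. Of the compounds shown here, two have been measured so far. Compound 1, `CCCCCCCCc1cn([C@H]2C[C@H](O)[C@@H](CO)O2)c(=O)[nH]c1=O`, gives 66 ug/mL in this assay. Compound 2, `CCCCCCc1cn([C@H]2C[C@H](O)[C@@H](CO)O2)c(=O)[nH]c1=O`, gives 172 ug/mL in this assay. Among the measured compounds shown here, of the two numbers measured, compound 2 stands at the higher one, and the only measured step, a 2.6-fold higher number from compound 1 to compound 2 (0.42 log units; beyond the scatter), leads there.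

Compound 3, `CCCCc1cn([C@H]2C[C@H](O)[C@@H](CO)O2)c(=O)[nH]c1=O`, has not yet been measured. It differs from compound 2 by hydrogen in place of ethyl on a saturated chain carbon, four bonds along the chain from an aromatic carbon. This is the same kind of shortening of the chain that separates compound 1 from compound 2, made again, two carbons further in.

For the measured compounds named here, the one step that bears on this change is a 2.6-fold higher number from compound 1 to compound 2 (0.42 log units; beyond the scatter). Taking that step as the guide, a further rise in the number is expected, of a comparable or somewhat larger size, so that compound 3 is estimated to be a weaker inhibitor than compound 2 in this assay, with a step of a 2.3-fold higher number from compound 2 to compound 3 (0.37 log units; beyond the scatter) expected. The estimate for compound 3 in this assay is 400 ug/mL, within a range from 200 ug/mL to 900 ug/mL.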

Compound 3, concentration for 50% inhibition: > 500 ug/mL
Compound 3 gave a limit, no number; the forecaster's own chance of this, stated with the estimate: 15%; middle value at least 1.2-fold (0.09 log units) from the limit.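

In this assay compound 3 stands at a limit of the assay and not at a number: the limit of > 500 ug/mL in this assay, at which 1 of the 3 values shown sits. Even so, the result shows that the direction of the earlier change holds when the same shortening is made again, four bonds along the chain from an aromatic carbon: the first removal of ethyl gave a 2.6-fold higher number from compound 1 to compound 2 (0.42 log units; beyond the scatter), and the second gives an at least 2.9-fold higher number from compound 2 to compound 3 (0.46 log units; beyond the scatter), so that inhibition weakens beyond the scatter both times. Taken as a single change, the loss of butyl gives an at least 7.5-fold higher number from compound 1 to compound 3 (0.87 log units; beyond the scatter), so in these three compounds the number rises with each shortening and none goes against this, although the true size of both steps into compound 3 stays unknown.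

The compounds shown leave open whether a longer chain than that of compound 1 would bring the number lower still or whether the trend would level off. They also leave open how this assay would respond to a chain of similar length ending in an amine or a carboxylic acid, since all three chains here are plain alkyl groups.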